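A few compounds are considered here, and "the series" means these few. Any claim that something is new, unique, unknown or untested is made for them only; others in the source may bear on it.

Measured in an ADME assay on L929 cells (Mus musculus) for cytotoxicity, read by resazurin assay, with a stated time of 48 h; on this read-out higher numbers stand for lower toxicity in this test and lower numbers for higher toxicity in this test:

- Compound 1 `C=Cn1c2ccc([N+](=O)[O-])cc2c(=O)n1Cc1ccccc1`: 160000 nM
- Compound 2 `COC(=O)CCn1c2ccc([N+](=O)[O-])cc2c(=O)n1Cc1ccccc1`: > 256000 nM (a limit)
- Compound 3 `CNC(=O)CCCn1c2ccc([N+](=O)[O-])cc2c(=O)n1Cc1ccccc1`: > 256000 nM (a limit)

Compound 3 has no exact number and stands at the limit of > 256000 nM in this assay, at which 2 of the 3 values shown sit. Compound 4 `O=c1c2cc([N+](=O)[O-])ccc2n(CCCO)n1Cc1ccccc1` keeps the shared core and changes 3-(methylcarbamoyl)propyl to 3-hydroxypropyl, with hydroxy in place of methylcarbamoyl on a saturated chain carbon, three bonds along the chain from an aromatic nitrogen.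

Going by the values given here, no measured step makes this exact change, but three alter the same substituent. The first is an at least 1.6-fold higher number from compound 1 to compound 3 (0.20 log units; that floor lies within the scatter), and the second is an at least 1.6-fold higher number from compound 1 to compound 2 (0.20 log units; that floor lies within the scatter). The third is a step that the two limits leave unreadable from compound 2 to compound 3. The two saturated chains therefore show no readable difference, and only the vinyl compound gives a number. No step beyond the scatter is expected in this assay, and the assay may again report only a limit. The expected change is a step that the limit leaves unreadable from compound 3 to compound 4. For compound 4 the estimate is 260000 nM, with an expected range from 130000 nM to 512000 nM.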

Compound 4, concentration lethal to 50% of the cells: > 256000 nM
Compound 4 gave a limit, no number; the forecaster's own chance of this, stated with the estimate: 65%; the middle value is on the limit's open side.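

In this assay compound 4 gives > 256000 nM as a limit and not a number. Going by these compounds alone, the only step that can be read is an at least 1.6-fold higher number from compound 1 to compound 4 (0.20 log units; that floor lies within the scatter); the steps from compound 2 and compound 3 to compound 4 cannot be read, as both ends are limits. A 3-hydroxypropyl chain, which carries no carbonyl, therefore gives the same limit in this test as the chains ending in methoxycarbonyl and methylcarbamoyl, so removing the methylcarbamoyl in favour of hydroxy does not bring the read-out down to a number: the limit of > 256000 nM in this assay, at which 3 of the 4 values shown sit.

The limits leave open how compound 2, compound 3 and compound 4 stand against one another. Also open, going by these compounds, is whether a chain ending in an amine or a carboxylic acid, or a longer chain, would give a number at this position.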